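A ring swap on the sulfonyl sulfur of compound 2

A few compounds are considered here, and "the series" means these few. Any claim that something is new, unique, unknown or untested is made for them only; others in the source may bear on it.

In an ADME assay on microsomes from liver (Mus musculus, strain CD-1) for pharmacokinetics, read by LC-MS, with a stated time of 60 min, tested at 1 uM (a lower number here means slower removal, a higher number faster removal of the compound), compound 1 (`O=C(NCc1cccnc1)Nc1ccc(S(=O)(=O)N2CCC3(CCNC3)CC2)cc1`) gives 44 mL/min/kg and compound 2 (`CC1CNCCN(S(=O)(=O)c2ccc(NC(=O)NCc3cccnc3)cc2)C1`) gives 48 mL/min/kg as its clearance. Among the compounds with values here, these two values lie within the scatter of each other, so compound 2 stands level with the only other measured compound. Compound 3 (`N[C@H]1CC[C@H](NS(=O)(=O)c2ccc(NC(=O)NCc3cccnc3)cc2)CC1`) keeps the shared core and differs from compound 2 only on the sulfonyl sulfur, where a group of 8 heavy atoms (6 carbon, 2 nitrogen; one six-membered non-aromatic ring of carbon only) in place of a group of 8 heavy atoms (6 carbon, 2 nitrogen; one seven-membered non-aromatic ring with 2 hetero atoms), on a sulfonyl sulfur describes the change. A (4-aminocyclohexyl)amino group, with its six-membered non-aromatic ring of carbon only, enters in place of the seven-membered non-aromatic ring with 2 hetero atoms. Within the data shown here, one measured step bears on this, and it also exchanged one group on that sulfur for another. With only a 1.1-fold higher number from compound 1 to compound 2 (0.04 log units; within the scatter) to go on, a step beyond the scatter is not expected for compound 3 in this assay and neither direction is favoured. This is thin evidence, as that single step did not bring in the (4-aminocyclohexyl)amino group, so the range stays wide. The expected change is a 1.1-fold lower number from compound 2 to compound 3 (0.06 log units; within the scatter) and it remains an estimate. For compound 3 the estimated clearance is 42 mL/min/kg with 20 mL/min/kg to 85 mL/min/kg as the expected range.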

Compound 3, clearance: 27 mL/min/kg
For compound 3 the middle estimate is 1.6-fold (0.19 log units) above the measured one; the measured number falls inside the stated range.
By their numbers in this assay, from the lowest: compounds 3, 1 and 2 (each within the scatter of the next).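

In this assay, the (4-aminocyclohexyl)amino group on the sulfonyl sulfur stays within the scatter of both earlier compounds, at a 1.8-fold lower number from compound 2 to compound 3 (0.25 log units; within the scatter) and a 1.6-fold lower number from compound 1 to compound 3 (0.21 log units; within the scatter). Within the data shown here, until now, the only step at this position had exchanged one group with hetero atoms in its rings for another; these two steps show that a six-membered non-aromatic ring of carbon only, with 2 defined stereocentres, can also stand there without a step beyond the scatter, so all three groups remain level in this assay. No measurement at hand accounts for the lower printed number of compound 3 or ties it to any feature of the group that entered.

Going by these compounds, what remains open is whether any group on the sulfonyl sulfur can give a step beyond the scatter, for example a plain cyclohexyl ring without an amine, a carboxylic acid on the cyclohexane ring, or an open aminoalkyl chain. The compounds shown also leave open how the other stereoisomer of the (4-aminocyclohexyl)amino group would compare with compound 3 in this assay.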